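The source may hold more compounds than are shown below. What is called first, only, known or untested is meant among the compounds shown, and "the series" means these compounds.

Within the data shown here, in a functional assay on HCT-116 cells (Homo sapiens) for antiproliferative activity, read by MTT assay, with a stated time of 72 h (a higher number here means a weaker inhibitor, a lower number a stronger inhibitor), two compounds built on the same core have numbers so far. Compound 1 `O=C(CCc1cccc2c1B(O)OC2)Nc1cccc(-c2ccc(F)cc2)c1` gives 550 nM, and compound 2 `COc1ccc(-c2cccc(NC(=O)CCc3cccc4c3B(O)OC4)c2)cc1` gives 160 nM, the lower of the two. Among the measured compounds shown here, the one measured step, methoxy in place of fluoro on an aromatic carbon, is a 3.4-fold lower number from compound 1 to compound 2 (0.54 log units; beyond the scatter), a modest change that lies beyond the scatter.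

Compound 3 `O=C(CCc1cccc2c1B(O)OC2)Nc1cccc(-c2ccc(OC(F)(F)F)cc2)c1` differs from compound 2 in a single group: trifluoromethyl in place of methyl on an oxygen on an aromatic ring. In other words, methoxy becomes trifluoromethoxy. The measured step bears on this change only indirectly, since it concerns the same substituent but neither measured compound carries the trifluoromethoxy group. The new group keeps the oxygen of compound 2, which stands at 160 nM, and it also carries fluorine, as does compound 1 at 550 nM. A small move toward a higher number is therefore expected, no larger than the measured step. The expected step is a 1.9-fold higher number from compound 2 to compound 3 (0.27 log units; within the scatter). Compound 3 is estimated at 300 nM, with an expected range of 110 nM to 800 nM.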

Compound 3, half-maximal inhibitory concentration: 730 nM
Compound 3: middle estimate off by 2.4-fold (0.39 log units), on the low side, and the stated range covers the measured number.
By their numbers in this assay, from the lowest: compound 2; then compounds 1 and 3 (each within the scatter of the next).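

In this assay, replacing the methyl on the oxygen with trifluoromethyl gives a 4.6-fold higher number from compound 2 to compound 3 (0.66 log units; beyond the scatter), so the lower number of compound 2 does not survive this change, even though the oxygen on the aromatic ring stays in place. The other step shows that the trifluoromethoxy group and the fluoro group cannot be told apart here: a 1.3-fold higher number from compound 1 to compound 3 (0.12 log units; within the scatter) lies within the scatter, leaving compound 2 as the only one of the three whose number stands apart from the others, with both of its steps beyond the scatter. Nothing in the information at hand accounts for why methoxy and trifluoromethoxy differ in this way, so the step stands as an observation without a cause.

Going by these compounds, three substituents are too few to define a trend, so it remains open whether a difluoromethoxy or ethoxy group would stay close to compound 2 or fall with compound 1 and compound 3. On these data alone, it is equally open whether a hydroxyl, an amine or a nitrile in the same place would bring the number lower still, and whether the gap between methoxy and trifluoromethoxy would persist with a longer chain on the shared core.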